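Notes on a phenyl-to-cyclohexyl change in the series

A few compounds are considered here, and "the series" means these few. Any claim that something is new, unique, unknown or untested is made for them only; others in the source may bear on it.

Measured so far:
compound 1 `O=C1COc2ccc(-c3cccc(NS(=O)(=O)c4ccc(F)cc4)c3)cc2N1c1ccccc1` — > 40000 nM in a functional assay on A549 cells (Homo sapiens) for antiproliferative activity, read by MTT assay, with a stated time of 72 h (on this read-out higher numbers stand for weaker inhibition and lower numbers for stronger inhibition), a limit of the assay
compound 2 `O=C1COc2ccc(-c3cnc(Cl)c(NS(=O)(=O)c4ccc(F)cc4)c3)cc2N1c1ccccc1` — 14700 nM
compound 3 `COc1ncc(-c2ccc3c(c2)N(C2CC2)C(=O)CO3)cc1NS(=O)(=O)c1ccc(F)cc1` — 3320 nM

Compound 1 sits at the limit (the limit of > 40000 nM in this assay, at which 1 of the 3 values shown sits); no number is known for it in this assay, only that it lies beyond the range recorded. Compound 2 and compound 3 give numbers, but each differs from compound 1 in more than one place, so their values show only where they sit, not what any single change does.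

Compound 4 `O=C1COc2ccc(-c3cccc(NS(=O)(=O)c4ccc(F)cc4)c3)cc2N1C1CCCCC1` differs from compound 1 by cyclohexyl in place of phenyl on an amide-type nitrogen in a ring. Within the data shown here, no measured step isolates this change. A moderate shift toward stronger inhibition is expected in this assay, an at least 2.0-fold lower number from compound 1 to compound 4 (0.30 log units; that floor lies within the scatter), though a value still at the limit is possible. Compound 4 is estimated at 20000 nM, with a range of 5000 nM to 60000 nM.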

Compound 4, half-maximal inhibitory concentration: 14500 nM
Compound 4: the middle estimate sits 1.4-fold (0.14 log units) above what was measured; the measured number falls inside the stated range.
By their numbers in this assay, from the lowest: compound 3; then compounds 4 and 2 (each within the scatter of the next). At a limit, above all of these: compound 1.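

In this assay, cyclohexyl in place of phenyl on an amide-type nitrogen in a ring gives an at least 2.7-fold lower number from compound 1 to compound 4 (0.44 log units; beyond the scatter), the one isolated change at this position among the compounds shown. The size of this step is a bound and not a number, because compound 1 sits at a limit: the limit of > 40000 nM in this assay, at which 1 of the 4 values shown sits.

Compound 4 gives a measured number, so an aromatic ring on this nitrogen is not needed for a reading within the range of this assay.

Going by these compounds, what a piperidinyl ring or an open hexyl chain does on this nitrogen stays open. Also open, on these data alone, is whether the same change carries over to the other cores, those of compound 2 and compound 3.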